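The source may report more compounds than this note shows. Statements on the series, on what has been measured and on what is new or still open speak of the compounds shown alone.

Compound 3 `O=S(=O)(c1ccccc1Cl)c1cn(C2CCCNC2)c2ncccc12` gives 3.7 nM in an assay on HeLa cells for displacement of a labelled ligand from 5-hydroxytryptamine receptor 6 (Homo sapiens); on this read-out lower numbers stand for stronger inhibition and higher numbers for weaker inhibition. Its neighbours are compound 1 `CN1CCC(n2cc(S(=O)(=O)c3ccccc3Cl)c3cccnc32)C1` with 2.2 nM and compound 2 `O=S(=O)(C1=C(Cl)NC2SC=CN12)c1cn(C2CCNC2)c2ncccc12` with 1 nM; the step of a 1.7-fold higher number from compound 1 to compound 3 (0.23 log units; within the scatter) lies within the scatter, whereas the gap between compound 2 and compound 3 is beyond it. Compound 4 `O=S(=O)(c1cccc(F)c1)c1cn(C2CCCNC2)c2ncccc12` differs from compound 3 by 3-fluorophenyl in place of 2-chlorophenyl on a sulfonyl sulfur. Among the compounds with values here, no measured step touches the group on the sulfonyl sulfur: the only step known, from compound 1 to compound 3, changes the group on the aromatic nitrogen, and compound 2 carries a different sulfonyl partner alongside a different amine. The change is therefore expected to give a modest step of a 1.6-fold higher number from compound 3 to compound 4 (0.21 log units; within the scatter), likely a somewhat higher number, in this assay. Compound 4 is estimated at 6 nM, between 2 nM and 20 nM.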

Compound 4, inhibition constant: 2.4 nM
Estimate against measurement, compound 4: 2.5-fold (0.40 log units) above; the measured number falls inside the stated range.
By their numbers in this assay, from the lowest: compound 2; then compounds 1, 4 and 3 (each within the scatter of the next).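

In this assay, within the data shown here, the step of a 1.5-fold lower number from compound 3 to compound 4 (0.19 log units; within the scatter) is the first to touch the group on the sulfonyl sulfur, and it shows that 3-fluorophenyl can stand in place of 2-chlorophenyl there without a shift beyond the scatter. The halogen and its ring position differ together in this pair, so neither can be read alone. No supporting evidence bears on this result. Still open, on these data alone, is how an unsubstituted phenyl, 3-chlorophenyl or a phenyl carrying an amine would read on the sulfonyl sulfur with piperidin-3-yl on the aromatic nitrogen.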